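The source may report more compounds than this note shows. Statements on the series, on what has been measured and on what is new or still open speak of the compounds shown alone.

Working notes on the series in an ADME assay on L02 cells (Homo sapiens) for cytotoxicity, read by MTT assay, with a stated time of 48 h; on this read-out lower numbers stand for stronger inhibition and higher numbers for weaker inhibition.

Compound 1 `O=C1O[C@@H](CN2CCC(c3ccc(F)cc3)CC2)CN1c1ccc(-n2cc(-c3ccccn3)cn2)c(F)c1` reaches only a limit of the assay in this assay, > 400 ug/mL. Compound 2 `CC(=O)OC[C@H]1CN(c2ccc(-n3cc(-c4ccccn4)cn3)c(F)c2)C(=O)O1` likewise gives only a limit, > 400 ug/mL. Among the measured compounds shown here, compound 3 `O=C1O[C@@H](Cn2ccnc2)CN1c1ccc(-n2cc(-c3ccccn3)cn2)c(F)c1` is the one member of the set with a number in this assay, 350 ug/mL; the other two values sit at the limit of > 400 ug/mL in this assay, at which 2 of the 3 values shown sit. For the measured compounds named here, the single measured step runs an at least 1.1-fold lower number from compound 2 to compound 3 (0.05 log units; that floor lies within the scatter), so the change from acetoxy to 1H-imidazol-1-yl carries no shift beyond the scatter, and the whole set lies in a narrow band at the weak end of this assay.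

Compound 4 `NC(=O)[C@H]1CN(c2ccc(-n3cc(-c4ccccn4)cn3)c(F)c2)C(=O)O1` differs from compound 3 as follows: carbamoyl in place of (1H-imidazol-1-yl)methyl on a saturated ring carbon. Going by the values given here, no measured step covers a carbamoyl group at this ring carbon. Among the compounds with values here, the only related step, from compound 2 to compound 3, is within the scatter, and the values of compound 1 and compound 2 are both limits, so there is no basis for expecting a step of any size beyond the scatter here; the expectation is that compound 4 stays in the same band as compound 3, with a fair chance that this assay again reports only a limit.

Compound 4 is therefore estimated at 400 ug/mL, with a range of 220 ug/mL to 700 ug/mL, which means an expected step of a 1.1-fold higher number from compound 3 to compound 4 (0.06 log units; within the scatter).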

Compound 4, half-maximal inhibitory concentration: 119 ug/mL
Compound 4: the middle estimate sits 3.4-fold (0.53 log units) above what was measured; measured number outside the range, below it.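

In this assay, the saturated ring carbon next to the ring oxygen proves sensitive to the group it bears: carbamoyl in place of (1H-imidazol-1-yl)methyl gives a 2.9-fold lower number from compound 3 to compound 4 (0.47 log units; beyond the scatter), whereas the exchange of acetoxy for 1H-imidazol-1-yl on the chain left the number within the scatter. Carbamoyl in place of acetoxymethyl points the same way, with an at least 3.3-fold lower number from compound 2 to compound 4 (0.52 log units; beyond the scatter), so compound 4 separates from both of these neighbours and the band that the earlier compounds suggested does not hold for this group. Compound 2 gives only a limit, so the second step is a floor and its true size cannot be read: the limit of > 400 ug/mL in this assay, at which 2 of the 4 values shown sit.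

The change to carbamoyl removes a five-membered aromatic ring, goes from 6 heavy atoms to 3 and brings in a hydrogen-bond donor all at once, and the compounds shown do not separate these features. On these data alone, whether a carboxylic acid, a primary amine or a longer chain ending in the same carbamoyl at this ring carbon would give a number like that of compound 4 stays open.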